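The compounds below may be only part of what the source reports. "The series", "measured", "known", "first", "only" and "open" are said of these compounds alone.

Working notes on the series. Compound 1 `CCOC(=O)C1=Cc2ccccc2OC1(OCc1cc(-c2ccc(C)cc2)no1)C(F)(F)F` carries on the shared core a five-membered ring bearing 4-methylphenyl on carbon; compound 2 `CCOC(=O)C1=Cc2ccccc2OC1(OCc1cn(CC(=O)Nc2ccccc2Br)nn1)C(F)(F)F` carries instead a five-membered ring with three nitrogens bearing the ((2-bromophenyl)carbamoyl)methyl group. In a functional assay on HeLa cells (Homo sapiens) for inhibition, read by MTT assay, with a stated time of 24 h (a lower number here means a stronger inhibitor, a higher number a weaker inhibitor), compound 1 gives only a limit of the assay, > 150000 nM. In this assay compound 2 likewise gives only a limit, > 150000 nM. For the measured compounds named here, both values sit at the limit of > 150000 nM in this assay, at which 2 of the 2 values shown sit, so compound 2 stands level with compound 1 and no measured step is available between them. Compound 3 `CCOC(=O)C1=Cc2ccccc2OC1(OCc1cn(-c2ccc(C)cc2)nn1)C(F)(F)F` differs from compound 2 in one place: 4-methylphenyl in place of ((2-bromophenyl)carbamoyl)methyl on an aromatic nitrogen. Compound 1, which already carries 4-methylphenyl on a five-membered ring, sits at the limit of > 150000 nM in this assay, at which 2 of the 2 values shown sit, and nothing shown points to a gain from this group. The step is expected to be none beyond the scatter, a number no higher from compound 2 to compound 3 (the limit leaves the size open). Compound 3 is expected to give 150000 nM in this assay, with a range from 50000 nM to 300000 nM and a high chance that only a limit is reported.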

Compound 3, half-maximal inhibitory concentration: 25100 nM
Compound 3: middle estimate off by 6.0-fold (0.78 log units), on the high side; the measured number lies below the stated range.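

For the compounds shown here, replacing ((2-bromophenyl)carbamoyl)methyl with 4-methylphenyl on the aromatic nitrogen gives an at least 5.9-fold lower number from compound 2 to compound 3 (0.77 log units; beyond the scatter) in this assay, the first readable step. This shows that the group on this nitrogen of the five-membered aromatic ring with 3 nitrogen can move a compound on the shared core off the assay limit, and that the smaller group, without the hydrogen-bond donor and acceptor of the group it replaces, is the better of this pair. Compound 3 is also the only compound shown with a number rather than a limit, so the size of the step stays open at its upper end and the change can be read only as a gain of at least the printed size: the limit of > 150000 nM in this assay, at which 2 of the 3 values shown sit.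

Going by these compounds alone, the single step changes the amide, the bromine and the link between ring and nitrogen together, so it leaves open which of these carries the gain. From the compounds shown here alone, how the same nitrogen responds to a plain phenyl, a benzyl group, a carboxylic acid or an amine also remains open, as does the part played by the methyl of 4-methylphenyl.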